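Replacing 4-hydroxy-3-methoxyphenyl with 4-bromophenyl

This account rests on a few compounds, and the source may have more. Where it says the series, first, only, none or still open, it means among the compounds named here.

Among the compounds with values here, in a functional assay on DU-145 cells (Homo sapiens) for inhibition, read by trypan blue exclusion, with a stated time of 96 h (a higher number here means a weaker inhibitor of growth, a lower number a stronger inhibitor of growth), compound 2 `COc1cc(/C=C(/Sc2ccc(Br)cc2)C(=O)c2ccc(Br)cc2)ccc1O` gives 1000 nM and stands level with compound 1 `O=C(/C(=C\c1ccc(Br)cc1)SCc1ccc(Cl)cc1)c1ccc(Br)cc1` at 1000 nM as the lowest of the three numbers so far. Compound 3 `O=C(/C(=C\c1c[nH]c2ccccc12)S(=O)(=O)Cc1ccc(F)cc1)c1ccc(Cl)cc1` gives 50000 nM and lies beyond the scatter on the higher side of both. Compound 4 `O=C(/C(=C\c1ccc(Br)cc1)Sc1ccc(Br)cc1)c1ccc(Br)cc1` has not yet been measured. The change from compound 2 is 4-bromophenyl in place of 4-hydroxy-3-methoxyphenyl on a double-bonded chain carbon bound to a double-bonded chain carbon and puts 4-bromophenyl in place of 4-hydroxy-3-methoxyphenyl on a double-bonded chain carbon bound to a double-bonded chain carbon. Within the data shown here, no measured pair isolates this change. Among the measured compounds shown here, compound 1 carries 4-bromophenyl at that same place and gives 1000 nM despite differing from compound 2 elsewhere, which is the only guide available. The estimated change is no change at the digits printed from compound 2 to compound 4 (within the scatter) and no step beyond the scatter is expected in this assay for this swap. Compound 4 is estimated at 1000 nM with 300 nM to 4000 nM as the expected range.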

Compound 4, concentration for 50% growth inhibition: 1000 nM
Compound 4: middle estimate and measured number agree at the digits printed, within the range that was stated.
By their numbers in this assay, from the lowest: compounds 1, 2 and 4 (each within the scatter of the next); then compound 3.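

In this assay the swap to 4-bromophenyl on a double-bonded chain carbon bound to a double-bonded chain carbon can now be read in a single place, and the step of no change at the digits printed from compound 2 to compound 4 (within the scatter) shows that 4-hydroxy-3-methoxyphenyl is not required there to hold this level of growth inhibition. The swap of 4-chlorobenzyl for 4-bromophenyl on a sulfur can also be read alone, and the step of no change at the digits printed from compound 1 to compound 4 (within the scatter) shows the same flat result at that second place. Both places therefore accept the groups compared so far without a step beyond the scatter.

On these data alone, whether an amine or a carboxylic acid on the double-bonded chain carbon, or a longer chain on the sulfur, would hold this level remains open. No measurement at hand bears on the reason for these flat steps.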